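Adding a third methoxy group to compound 2

This account rests on a few compounds, and the source may have more. Where it says the series, first, only, none or still open, it means among the compounds named here.

Compound 1 has the structure `COc1cccc(/C=C/C(=O)OCc2nc(C)c(C)nc2C)c1`. In a functional assay on PC-12 cells (Rattus norvegicus) (a higher number here means that more compound is needed for the effect, a lower number that less compound is needed), compound 1 gives < 24000 nM, a limit of the assay and not a number. Compound 2 has the structure `COc1cccc(/C=C/C(=O)OCc2nc(C)c(C)nc2C)c1OC`. In this assay compound 2 gives < 24000 nM, again a limit and not a number. The step that the two limits leave unreadable from compound 1 to compound 2 therefore cannot be sized; what both compounds share is the limit of < 24000 nM in this assay, at which 2 of the 2 values shown sit, so compound 2 stands only at that limit and cannot be ranked against compound 1.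

Compound 3 has the structure `COc1ccc(/C=C/C(=O)OCc2nc(C)c(C)nc2C)c(OC)c1OC`. It differs from compound 2 by methoxy in place of hydrogen on an aromatic carbon. Going by the values given here, the only measured step that bears on this change is the one from compound 1 to compound 2, also a methoxy entering on an aromatic carbon, and its size is not readable. Among the compounds with values here, no measured step therefore fixes a direction or size for the change in this assay; the expectation rests only on both known compounds sitting at the same limit. Compound 3 is estimated at 10000 nM, with a range from 2000 nM to 30000 nM. The expected step that the limit leaves unreadable from compound 2 to compound 3 is a working guess only.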

Compound 3, half-maximal effective concentration: 719 nM
Compound 3: the middle estimate sits 14-fold (1.14 log units) above what was measured, and the stated range ends above it.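

No step from compound 2 to compound 3 can be read in this assay, as compound 2 is known only by a limit of the assay and not by a number: the limit of < 24000 nM in this assay, at which 2 of the 3 values shown sit.

The compounds shown leave open how far the methoxy entering on the aromatic carbon moves the value in this assay, and whether compound 1 and compound 2 differ there at all.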